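A few compounds are considered here, and "the series" means these few. Any claim that something is new, unique, unknown or untested is made for them only; others in the source may bear on it.

Compound 1 `CCN(CC)Cc1cc(Cl)cc2c(=O)cc(-c3ccc([N+](=O)[O-])cc3)oc12` was tested in a functional assay on HepG2 cells (Homo sapiens) for cytotoxicity, read by MTT assay, with a stated time of 48 h (on this read-out lower numbers stand for stronger inhibition and higher numbers for weaker inhibition), where compound 1 gives 1190 nM. Compound 2 `O=c1cc(-c2ccc([N+](=O)[O-])cc2)oc2c(CN3CCCCC3)cc(Cl)cc12` differs from it only by piperidin-1-yl in place of diethylamino on a saturated chain carbon bound to an aromatic carbon; in this assay compound 2 gives 8910 nM, a step of a 7.5-fold higher number from compound 1 to compound 2 (0.87 log units; beyond the scatter). Compound 3 `CCN(CC)Cc1cc(Cl)cc2c(=O)cc(-c3ccccc3Cl)oc12` keeps the diethylamino group but carries a different ring on the shared core, the difference being (2-chlorophenyl in place of 4-nitrophenyl on an aromatic carbon); in this assay compound 3 gives 7940 nM, a step of a 6.7-fold higher number from compound 1 to compound 3 (0.82 log units; beyond the scatter). Compound 4 `O=c1cc(-c2ccccc2Cl)oc2c(CN3CCCCC3)cc(Cl)cc12` has not been measured. It differs from compound 3 by piperidin-1-yl in place of diethylamino on a saturated chain carbon bound to an aromatic carbon, the same change that turns compound 1 into compound 2, made at a place described in the same words. A step of similar direction is expected here because the earlier one read a 7.5-fold higher number from compound 1 to compound 2 (0.87 log units; beyond the scatter), measured from compound 1 at 1190 nM. Compound 4 is therefore expected to give about 40000 nM in this assay, roughly between 13000 nM and 120000 nM, which would mean an expected step of a 5.0-fold higher number from compound 3 to compound 4 (0.70 log units; beyond the scatter).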

Compound 4, half-maximal inhibitory concentration: 10700 nM
Beside the measured number, compound 4's estimate is 3.7-fold (0.57 log units) above it; measured number below the stated range.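

In this assay, piperidin-1-yl in place of diethylamino gives a 1.3-fold higher number from compound 3 to compound 4 (0.13 log units; within the scatter), so with 2-chlorophenyl on the shared core this change does not repeat the size it had with 4-nitrophenyl: the same change on two cores in this assay, a 7.5-fold higher number (0.87 log units; beyond the scatter) from compound 1 to compound 2 and a 1.3-fold higher number (0.13 log units; within the scatter) from compound 3 to compound 4, 5.6-fold (0.74 log units) apart, beyond the scatter of two such steps. Read the other way, 2-chlorophenyl in place of 4-nitrophenyl gives a 1.2-fold higher number from compound 2 to compound 4 (0.08 log units; within the scatter), so the size of that change also depends on which amine is present: the same change on two cores in this assay, a 6.7-fold higher number (0.82 log units; beyond the scatter) from compound 1 to compound 3 and a 1.2-fold higher number (0.08 log units; within the scatter) from compound 2 to compound 4, 5.6-fold (0.74 log units) apart, beyond the scatter of two such steps. The two changes therefore do not add up independently in these four compounds, but this does not show why, or how either change would behave on another core.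

On these data alone, it remains open how the piperidin-1-yl step would read with a third ring, such as 4-methoxyphenyl, on the shared core. As far as these compounds go, how a morpholin-4-yl group on the same saturated chain carbon would compare also remains open.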